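Methyl for Trifluoromethyl on the Oxadiazole of Compound 1

The source may report more compounds than this note shows. Statements on the series, on what has been measured and on what is new or still open speak of the compounds shown alone.

Compound 1, `CCN(CC)S(=O)(=O)c1ccc(S(=O)(=O)N2CCC[C@@H](C(=O)N3CCN(c4nc(C(F)(F)F)no4)CC3)C2)cc1`, in a functional assay on MIA PaCa-2 cells (Homo sapiens) for inhibition, read by MTT assay, with a stated time of 3 days (a higher number here means a weaker inhibitor, a lower number a stronger inhibitor), reaches only the limit > 10000 nM.
Compound 2, `CCN(CC)S(=O)(=O)c1ccc(S(=O)(=O)N2CCC[C@@H](C(=O)N3CCC(c4nc(C(C)C)no4)CC3)C2)cc1`, in this assay likewise reaches only the limit > 10000 nM.
Compound 3, `CCOC(=O)[C@@H]1CCCN(S(=O)(=O)c2ccc(S(=O)(=O)N(CC)CC)cn2)C1`, in this assay also reaches only the limit > 10000 nM.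

Among the measured compounds shown here, compound 1 therefore stands nowhere on a scale of numbers: its result is a limit, and the same holds for the two other compounds measured alongside it, so that no ordering among the three can be read and no step between any pair of them is known. The account turns to compound 4, `CCN(CC)S(=O)(=O)c1ccc(S(=O)(=O)N2CCC[C@@H](C(=O)N3CCN(c4nc(C)no4)CC3)C2)cc1`, which differs from compound 1 in a single place: methyl in place of trifluoromethyl on an aromatic carbon.

For the measured compounds named here, with no measured step to lean on, the expectation for this assay rests on (the limit of > 10000 nM in this assay, at which 3 of the 3 values shown sit), which leaves the direction of any change from compound 1 to compound 4 open; nothing in the data points to a gain beyond the scatter. Compound 4 is therefore expected to give 15000 nM, with a plausible range from 5000 nM to 50000 nM, most likely again as a limit. The estimated step that the limit leaves unreadable from compound 1 to compound 4 is thus expected to be none beyond the scatter.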

Compound 4, half-maximal inhibitory concentration: > 10000 nM
Compound 4 gave a limit, no number; the forecaster's own chance of this, stated with the estimate: 85%; the middle value lies beyond the limit too.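

Compound 4 in this assay gives > 10000 nM, which is a limit and not a number. No step between compound 1 and compound 4 can be read: the limit of > 10000 nM in this assay, at which 4 of the 4 values shown sit.

The compounds shown leave open whether methyl and trifluoromethyl differ at all in this assay, and whether any change to the shared core would yield a number rather than a limit.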